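Replacing cyclohexylmethyl by 4-chlorophenyl on the shared core

The source may report more compounds than this note shows. Statements on the series, on what has been measured and on what is new or still open speak of the compounds shown alone.

Compound 3 `Cc1nc2c(cnn2CC2CCCCC2)c(=O)n1-c1ccc(Cl)cc1` is one of three compounds with numbers in an in vitro functional assay on cells for antagonist activity at metabotropic glutamate receptor 1 (Homo sapiens), read by FLIPR and calcium flux; on this read-out lower numbers stand for stronger inhibition and higher numbers for weaker inhibition. In this assay compound 3 gives only a limit, > 100000 nM. Compound 1 `Cc1nc2c(cnn2-c2ccccc2)c(=O)n1N1CCCCC1` in this assay gives 91 nM. Within the data shown here, compound 2 `Cc1nc2c(cnn2-c2ccccc2)c(=O)n1N1CCCCCC1` in this assay gives 240 nM; the single measured step of a 2.6-fold higher number from compound 1 to compound 2 (0.42 log units; beyond the scatter) concerns a different position on the shared core and so does not bear directly on the change considered here. Compound 4 `Cc1nc2c(cnn2-c2ccc(Cl)cc2)c(=O)n1-c1ccc(Cl)cc1` differs from compound 3 by 4-chlorophenyl in place of cyclohexylmethyl on an aromatic nitrogen. Among the measured compounds shown here, compounds 1 and 2, which also carry an aromatic group on an aromatic nitrogen of the five-membered aromatic ring, differ from compound 4 in more than one place, so their values show only that such compounds can reach the numbers quoted for them. Given the limit for compound 3 (the limit of > 100000 nM in this assay, at which 1 of the 3 values shown sits), the estimated step of an at least 33-fold lower number from compound 3 to compound 4 (1.52 log units; beyond the scatter) is expected to bring compound 4 into a measurable range. Compound 4 is therefore estimated at 3000 nM in this assay, with a range from 200 nM to 50000 nM.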

Compound 4, half-maximal inhibitory concentration: 1100 nM
Beside the measured number, compound 4's estimate is 2.7-fold (0.44 log units) above it; low and high end bracket the measured number.
By their numbers in this assay, from the lowest: compound 1; then compound 2; then compound 4. At a limit, above all of these: compound 3.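

In this assay, 4-chlorophenyl in place of cyclohexylmethyl on an aromatic nitrogen of the five-membered aromatic ring gives an at least 90-fold lower number from compound 3 to compound 4 (1.95 log units; beyond the scatter), so this position responds strongly to the group it carries, even though both groups have the same count of heavy atoms. This is the only step shown at this position, as the earlier step from piperidin-1-yl to azepan-1-yl lies elsewhere on the shared core. The full size of the new step cannot be read because compound 3 stands at a limit: the limit of > 100000 nM in this assay, at which 1 of the 4 values shown sits.

The compounds shown leave open whether the change follows from the aromatic ring or from its chlorine, which a plain phenyl at this position on the core of compound 4 would separate. Also open, from the compounds shown here alone, is how a methoxy group or an amine in place of that chlorine would fare.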